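The source may hold more compounds than are shown below. What is called first, only, known or untested is meant among the compounds shown, and "the series" means these compounds.

In an ADME assay on a cell-free system (plasma, Rattus norvegicus) for metabolic stability, read by LC-MS, with a stated time of 60 min, tested at 100 uM (a higher number here means that more of the compound is left, a lower number that less of the compound is left), three compounds have been examined so far. Compound 1 `COc1cc(C(=O)O)ccc1OCCCCOc1ccc(C(=O)CC(C)C)c(O)c1C` gives 99%. Compound 2 `Cc1c(OCCCCOc2ccc(C(=O)O)cc2Cl)ccc(C(=O)CC2CCCC2)c1O` gives 120%, and compound 3 `Cc1c(OCCCCOc2cccc(C(=O)O)c2)ccc(C(=O)CC(C)C)c1C` gives 106%. Compound 2 stands highest of the three numbers; compound 3 is nearest to it, and the gap between them lies beyond the scatter, while compound 1 is furthest from it, that gap also lying beyond the scatter.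

Compound 4 `COc1ccc(C(=O)O)cc1OCCCCOc1ccc(C(=O)CC2CCCC2)c(O)c1C` has not yet been measured in this assay. It differs from compound 2 in one place: 5-carboxy-2-methoxyphenyl in place of 4-carboxy-2-chlorophenyl on an oxygen on a saturated carbon. Among the measured compounds shown here, no step between two measured compounds covers this exact change, so the expectation for compound 4 rests on the spread of the three numbers seen so far, all of which describe compounds of which most is left after the stated time. Compound 4 is therefore expected to show a small downward step from compound 2, of roughly a number 14 percentage points lower from compound 2 to compound 4 (beyond the scatter), close to the edge of the scatter. In this assay compound 4 is estimated at 106%, with a range from 92% to 120%.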

Compound 4, percent of the compound remaining: 103%
Compound 4: the middle estimate sits 3 percentage points above what was measured; the measured number falls inside the stated range.
By their numbers in this assay, from the lowest: compounds 1, 4 and 3 (each within the scatter of the next); then compound 2.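

In this assay, among the compounds shown here, replacing 4-carboxy-2-chlorophenyl with 5-carboxy-2-methoxyphenyl on an oxygen on a saturated carbon gives a number 17 percentage points lower from compound 2 to compound 4 (beyond the scatter), the first direct reading of a change at this position. Even after this step, compound 4 gives 103%, so most of the compound is still left after the stated time. Nothing available accounts for the size or direction of this step.

The entering and leaving groups differ both in carrying methoxy or chloro and in the numbering of the carboxy group, and this single step cannot separate those two differences. Going by these compounds, how an ester or an amine in place of the carboxylic acid on this ring would read in this assay also remains open.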